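This account rests on a few compounds, and the source may have more. Where it says the series, first, only, none or still open, it means among the compounds named here.

Three compounds built on one shared core have so far been examined in an assay on isolated protein for displacement of a labelled ligand from metabotropic glutamate receptor 5 (Homo sapiens), with a stated time of 60 min, tested at 1 uM; a higher number here means more inhibition at the concentration tested (going by the name of the read-out), a lower number less inhibition. Compound 1 `CCN1CCN(c2c(S(=O)(=O)c3ccccc3)cnc3ccccc23)CC1` gives 1.7%, compound 2 `CN1CCN(c2c(S(=O)(=O)c3ccccc3)cnc3ccccc23)CC1` gives 7.7% and compound 3 `O=S(=O)(c1ccccc1)c1cnc2ccccc2c1N1CCCCC1` gives 71.4%. Compound 2 stands second highest of the three numbers; its nearest neighbour is compound 1, and the step of a number 6 percentage points higher from compound 1 to compound 2 (within the scatter), so the two cannot be told apart. Compound 3 stands far from both, with a number 69.7 percentage points higher from compound 1 to compound 3 (beyond the scatter) and a number 63.7 percentage points higher from compound 2 to compound 3 (beyond the scatter).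

Compound 4 `O=S(=O)(c1ccccc1)c1cnc2ccccc2c1N1CCN(c2ccccc2)CC1` has not yet been measured. It differs from compound 2 in one place: phenyl in place of methyl on an amine nitrogen in a ring.

Going by the values given here, two measured steps bear on this change. The step of a number 6 percentage points higher from compound 1 to compound 2 (within the scatter) altered the group on the same ring nitrogen and stayed within the scatter. The step of a number 63.7 percentage points higher from compound 2 to compound 3 (beyond the scatter) was large, but it exchanged the whole ring rather than the group on its nitrogen, so it is a weaker guide. Nothing measured fixes the size of a phenyl at that position. For compound 4 a modest rise is expected, a number 17.3 percentage points higher from compound 2 to compound 4 (beyond the scatter), with wide uncertainty. Compound 4 is therefore estimated at 25% in this assay, within a range from 0% to 60%.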

Compound 4, a percentage reported as inhibition, at one concentration (the size of the read-out at that concentration, not a potency): 13.5%
For compound 4 the middle estimate is 11.5 percentage points above the measured one; the range from low to high includes it.
By their numbers in this assay, from the lowest: compounds 1, 2 and 4 (each within the scatter of the next, the first and the last beyond it); then compound 3.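

In this assay, the exchange of methyl for phenyl on the amine nitrogen in the ring is a number 5.8 percentage points higher from compound 2 to compound 4 (within the scatter), so a group of 6 heavy atoms carrying an aromatic ring cannot be told apart from a single carbon at this position. Going by these compounds alone, measured against ethyl, phenyl gives a number 11.8 percentage points higher from compound 1 to compound 4 (beyond the scatter), the first step among groups on this nitrogen to clear the scatter, yet it is modest, and with phenyl there compound 4 stands at 13.5%, still far from compound 3 at 71.4%. No measurement is available that would account for these numbers.

The compounds shown leave open what a benzyl group, an acetyl group or plain hydrogen on that nitrogen would give, and whether a substituted phenyl would behave like the unsubstituted one. They also leave open whether morpholin-4-yl in place of the whole ring would give a number closer to that of compound 3 or to those of the piperazine compounds, which would help show how much depends on the ring itself rather than on the group its nitrogen carries.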